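Swapping the aryl group on a weakly active alkene analogue

The source may hold more compounds than are shown below. What is called first, only, known or untested is meant among the compounds shown, and "the series" means these compounds.

Measured so far:
Compound 1, `CC(C)(C)c1cn(C[C@H](O)[C@H]2OC(=O)C(OCc3ccccc3)=C2OCc2ccccc2)nn1`, in a functional assay on A549 cells (Homo sapiens) for antiproliferative activity, read by MTT assay, with a stated time of 72 h (on this read-out lower numbers stand for stronger inhibition and higher numbers for weaker inhibition), gives 34000 nM.
Compound 3, `Cc1ccc(S(=O)(=O)NCc2cn(C[C@H](O)[C@H]3OC(=O)C(OCc4ccccc4)=C3OCc3ccccc3)nn2)cc1`, in this assay gives 16800 nM.
Compound 2, `COc1ccc(-c2cn(C/C=C3\OC(=O)C(OCc4ccccc4)=C3OCc3ccccc3)nn2)cc1`, in this assay gives only a limit of the assay, > 100000 nM.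

Compound 2 thus stands at the weak end of the values shown, at the limit of > 100000 nM in this assay, at which 1 of the 3 values shown sits. The unmeasured compound 4, `O=C1O/C(=C\Cn2cc(-c3cc(F)cc(F)c3)nn2)C(OCc2ccccc2)=C1OCc1ccccc1`, differs from compound 2 in one place: 3,5-difluorophenyl in place of 4-methoxyphenyl on an aromatic carbon. Within the data shown here, the only measured step, a 2.0-fold lower number from compound 1 to compound 3 (0.31 log units; beyond the scatter), changes a different group on a different pair of compounds and does not bear on this exchange. Among the measured compounds shown here, no measured step informs the size or direction of the change from compound 2 to compound 4, so no step beyond the scatter is expected, a number no higher from compound 2 to compound 4 (the limit leaves the size open). Compound 4 is therefore estimated at 100000 nM, within 30000 nM to 300000 nM, with a fair chance that it again reaches only a limit.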

Compound 4, half-maximal inhibitory concentration: > 100000 nM
Compound 4 ended at the assay's limit (the forecaster's own chance of this, stated with the estimate: 55%); the middle value sits exactly at the limit.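

Compound 2 and compound 4 both reach only a limit in this assay, so no step between them can be read: the limit of > 100000 nM in this assay, at which 2 of the 4 values shown sit.

The compounds shown leave open whether 3,5-difluorophenyl in place of 4-methoxyphenyl changes the activity at all.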